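The source may hold more compounds than are shown below. What is called first, only, known or untested is meant among the compounds shown, and "the series" means these compounds.

Of the compounds shown here, three of the shared core have been measured in an assay on CHO cells for displacement of a labelled ligand from prostaglandin D2 receptor 2 (Homo sapiens), read by scintillation counting; on this read-out lower numbers stand for stronger inhibition and higher numbers for weaker inhibition. Compound 1 `Cc1ccc(S(=O)(=O)CCO)cc1C#Cc1cc(Cl)ccc1OCC(=O)O` gives 19 nM, compound 3 `CS(=O)(=O)Cc1cccc(C#Cc2cc(Cl)ccc2OCC(=O)O)c1` gives 48 nM, and compound 2 `O=C(O)COc1ccccc1C#Cc1ccccc1Cl` gives 747 nM. Compound 1 thus shows the lowest number of the three, and its gaps to compound 3 and to compound 2 both lie beyond the usual scatter of repeated measurements. Compound 4 `Cc1ccc(S(=O)(=O)N2CCOCC2)cc1C#Cc1cc(Cl)ccc1OCC(=O)O` has not yet been measured; it differs from compound 1 in one place: morpholin-4-yl in place of 2-hydroxyethyl on a sulfonyl sulfur. Going by the values given here, no measured pair carries this change, so no direct guide exists. The step is expected to be a modest weakening, a 1.8-fold higher number from compound 1 to compound 4 (0.27 log units; within the scatter), in this assay. On that basis compound 4 is expected to give 35 nM in this assay, with a range from 10 nM to 120 nM.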

Compound 4, inhibition constant: 3.6 nM
Beside the measured number, compound 4's estimate is 9.7-fold (0.99 log units) above it; measured number below the stated range.
By their numbers in this assay, from the lowest: compound 4; then compound 1; then compound 3; then compound 2.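

Replacing 2-hydroxyethyl with morpholin-4-yl on a sulfonyl sulfur gives in this assay a 5.3-fold lower number from compound 1 to compound 4 (0.72 log units; beyond the scatter), so this position accepts a six-membered non-aromatic ring with a gain rather than a loss. The hydrogen-bond donor of 2-hydroxyethyl is therefore not needed for a low number in this series. Nothing measured here explains the step.

The compounds shown leave open whether the ring oxygen of morpholin-4-yl contributes, which piperidin-1-yl on the same sulfur would address. Going by these compounds, whether a ring is needed at all also remains open, and an open-chain dimethylamino group there would bear on that.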